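Branching a Short Chain in Two Related Series

The compounds below may be only part of what the source reports. "The series", "measured", "known", "first", "only" and "open" are said of these compounds alone.

Three compounds were measured in an assay on membranes from CHO cells for displacement of a labelled ligand from adenosine receptor A1 (Homo sapiens), read by scintillation counting, with a stated time of 60 min, tested at 1 uM; a lower number here means less inhibition, a higher number more inhibition at the concentration tested (going by the name of the read-out). Compound 1 `CCCOC(=O)C1=C(C)NC(=S)NC1c1ccsc1` gives 5% in this assay. Compound 2 `CC1=C(C(=O)OCC(C)C)C(c2ccsc2)NC(=S)N1` differs from compound 1 by methyl in place of hydrogen on a saturated chain carbon bound to two saturated chain carbons; in this assay compound 2 gives 8%, so the step is a number 3 percentage points higher from compound 1 to compound 2 (within the scatter). Compound 3 `CCSC(=O)C1=C(C)NC(=O)NC1c1ccsc1` gives 11% in this assay; the difference between its core and the core of compound 1 is not broken down here. Compound 4 `CC1=C(C(=O)SC(C)C)C(c2ccsc2)NC(=O)N1` has not yet been measured. It differs from compound 3 by methyl in place of hydrogen on a saturated chain carbon bound to a saturated chain carbon and a sulfur, the same kind of change as from compound 1 to compound 2, though the place is a saturated chain carbon bound to a saturated chain carbon and a sulfur rather than one bound to two saturated chain carbons. The expected step is a number 3 percentage points higher from compound 3 to compound 4 (within the scatter), resting on the step of a number 3 percentage points higher from compound 1 to compound 2 (within the scatter). Compound 4 is estimated at 14%, with a range from 4% to 24%.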

Compound 4, a percentage reported as inhibition, at one concentration (the size of the read-out at that concentration, not a potency): 24%
Compound 4: middle estimate off by 10 percentage points, on the low side; measured number inside the range.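

Exchanging ethylsulfanyl for isopropylsulfanyl in this assay gives a number 13 percentage points higher from compound 3 to compound 4 (beyond the scatter). Set beside the earlier step, the same change does not differ measurably between the two cores: the same change on two cores in this assay, a number 3 percentage points higher (within the scatter) from compound 1 to compound 2 and a number 13 percentage points higher (beyond the scatter) from compound 3 to compound 4, 10 percentage points apart, within the scatter of two such steps The result is thus compatible with the change carrying over from one core to the other, but it does not show that the two steps are equal, nor that either core responds more strongly, and it rests on a single pair on each core.

The compounds shown leave open what a longer chain, such as butyl, or a cyclopentyl group would do in the same place. They also leave open whether either core would follow the same course with those groups.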